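This account rests on a few compounds, and the source may have more. Where it says the series, first, only, none or still open, it means among the compounds named here.

Of the compounds shown here, three built on one shared core have been measured in an assay on CHO cells for displacement of a labelled ligand from adenosine receptor A1 (Homo sapiens), read by scintillation counting, with a stated time of 3 h; on this read-out lower numbers stand for stronger inhibition and higher numbers for weaker inhibition. Compound 1 `COc1ccc(-c2nc3c(NC4CCCC4)ncnc3n2C)cc1` gives 75 nM. Compound 2 `CCn1c(-c2ccccc2)nc2c(NC3CCC3)ncnc21` gives 6 nM. Compound 3 `CCCn1c(-c2ccccc2)nc2c(NC3CCC3)ncnc21` gives 15 nM. On these numbers compound 3 stands second highest of the three, with compound 2 as its nearest neighbour and compound 1 as its furthest. For the measured compounds named here, the only step between two compounds that differ in a single place is a 2.5-fold higher number from compound 2 to compound 3 (0.40 log units; beyond the scatter), which comes from a methyl in place of hydrogen on a saturated chain carbon, two bonds along the chain from an aromatic nitrogen.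

Compound 4 `CCCn1c(-c2ccccc2)nc2c(NC3CCCC3)ncnc21` has not yet been measured in this assay. It differs from compound 3 in one place: cyclopentyl in place of cyclobutyl on a nitrogen on an aromatic ring. Going by the values given here, no measured step alters this ring, so the only guide is the modest chain-lengthening step just described, which touched a different part of the molecule. Among the compounds with values here, compound 1 does carry a cyclopentyl on that nitrogen, but it differs from compound 4 in more than one place, so its value shows only that this ring is compatible with binding.

For compound 4 a value of 12 nM is expected, with a range from 4 nM to 40 nM. The step this estimate implies, a 1.3-fold lower number from compound 3 to compound 4 (0.10 log units; within the scatter), is expected to stay near the scatter, with no clear direction.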

Compound 4, inhibition constant: 10 nM
Estimate against measurement, compound 4: 1.2-fold (0.08 log units) above; the measured number falls inside the stated range.
By their numbers in this assay, from the lowest: compounds 2, 4 and 3 (each within the scatter of the next, the first and the last beyond it); then compound 1.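

In this assay, cyclopentyl in place of cyclobutyl on a nitrogen on an aromatic ring gives a 1.5-fold lower number from compound 3 to compound 4 (0.18 log units; within the scatter), so this pair cannot be told apart on this read-out. For the compounds shown here, this is the first direct reading of a change at this position, as the earlier step concerned only the saturated chain, and it shows that a five-membered carbon ring can take the place of a four-membered one here without a change beyond the scatter. No measurement on hand explains why the two rings read alike.

The compounds shown leave open how much further this position can be varied, for instance with a smaller cyclopropyl ring, a larger cyclohexyl ring, an open isopropyl chain or a ring that contains an oxygen. They also leave open whether cyclopentyl and cyclobutyl would still read alike with the shorter chain of compound 2, or whether the result holds only with the chain that compound 3 and compound 4 share.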